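The source may report more compounds than this note shows. Statements on the series, on what has been measured and on what is new or still open speak of the compounds shown alone.

Measured compounds in a functional assay, tested at 400 ug/mL; a higher number here means a stronger effect of the compound at the concentration tested, a lower number a weaker effect:
- compound 1 `N#CC1=C(N)OC(c2c[nH]c3ccccc23)=C(C#N)C1c1cccc2ccccc12`: 10.4%
- compound 2 `N#CC1=C(N)OC(c2c[nH]c3ccccc23)=C(C#N)C1c1ccccc1Cl`: 21.4%
- compound 3 `N#CC1=C(N)OC(c2c[nH]c3ccccc23)=C(C#N)C1c1ccc2ccccc2c1`: "not active" (no number reported), with no number reported

Compound 3 therefore stands without a figure; only compounds 1 and 2 give numbers in this assay. The step to compound 4 `Cc1ccc(C2C(C#N)=C(N)OC(c3c[nH]c4ccccc34)=C2C#N)cc1` is 4-methylphenyl in place of naphthalen-2-yl on a saturated ring carbon. Among the measured compounds shown here, the one measured step that bears on it, a number 11 percentage points higher from compound 1 to compound 2 (beyond the scatter), also exchanged a group of two six-membered aromatic rings of carbon only for a single six-membered aromatic ring on a saturated ring carbon, and was modest. A modest gain of similar size is expected here, though compound 3 supplies no starting number, so the footing is weak. Compound 4 is expected to give 15%, in the range 0% to 35%.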

Compound 4, a percentage reported as activity, at one concentration (the size of the read-out at that concentration, not a potency): 8.5%
Beside the measured number, compound 4's estimate is 6.5 percentage points above it; the measured number falls inside the stated range.
By their numbers in this assay, from the lowest: compounds 4 and 1 (each within the scatter of the next); then compound 2.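

In this assay, a single six-membered aromatic ring on the saturated ring carbon does not by itself carry the higher number: 4-methylphenyl in place of 2-chlorophenyl gives a number 12.9 percentage points lower from compound 2 to compound 4 (beyond the scatter). Against naphthalen-1-yl, 4-methylphenyl gives a number 1.9 percentage points lower from compound 1 to compound 4 (within the scatter), so compound 4 goes against the gain seen with compound 2. The step from compound 3 cannot be read, and no supporting data explain these differences.

Open, from the compounds shown here alone, is whether the chlorine itself accounts for the number of compound 2. Also open, going by these compounds, is what a methoxy group or an amine on the single ring would give.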